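The compounds below may be only part of what the source reports. "The series", "measured", "known", "first", "only" and "open" are said of these compounds alone.

Working notes on the series. Compound 1 `Cc1noc(C)c1-c1cnc(N)c(Oc2ccc(C(=O)Nc3ccccc3)cc2)n1` carries the shared core with a phenylcarbamoyl group, and in a functional assay on HepG2 cells (Homo sapiens) for inhibition, read by MTT assay, with a stated time of 72 h (on this read-out higher numbers stand for weaker inhibition and lower numbers for stronger inhibition), compound 1 gives 11800 nM. Compound 2 `Cc1noc(C)c1-c1cnc(N)c(Oc2ccc(C(=O)Nc3ccccc3Cl)cc2)n1` differs from compound 1 only by chloro in place of hydrogen on an aromatic carbon. For compound 2 the assay reports only a limit, > 100000 nM. The step of an at least 8.4-fold higher number from compound 1 to compound 2 (0.92 log units; beyond the scatter) therefore runs up to that limit (the limit of > 100000 nM in this assay, at which 1 of the 3 values shown sits). Compound 3 `Cn1cc(-c2cnc(N)c(Oc3ccc(C(=O)Nc4ccccc4)cc3)n2)cn1` has 1-methyl-1H-pyrazol-4-yl in place of 3,5-dimethyl-1,2-oxazol-4-yl, and in this assay compound 3 gives 11600 nM; the step of a 1.0-fold lower number from compound 1 to compound 3 (0.01 log units; within the scatter) is within the scatter. Compound 3 thus holds the lowest of the two numbers, with compound 1 within the scatter of it, while the third value shown is a limit.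

Compound 4 `Cn1cc(-c2cnc(N)c(Oc3ccc(C(=O)Nc4ccccc4Cl)cc3)n2)cn1` is the unmeasured partner of compound 3: chloro in place of hydrogen on an aromatic carbon, on an aromatic carbon of a six-membered aromatic ring of carbon only, ortho to a large group. Within the data shown here, the one measured step bearing on this change is an at least 8.4-fold higher number from compound 1 to compound 2 (0.92 log units; beyond the scatter), at least modest and ending at the limit. An upward step of similar size in this assay is therefore expected, and the number for compound 4 may again come back only as a limit. The estimate for compound 4 is 100000 nM, with a range from 30000 nM to 300000 nM. This estimate means an expected step of an 8.6-fold higher number from compound 3 to compound 4 (0.94 log units; beyond the scatter).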

Compound 4, half-maximal inhibitory concentration: 66900 nM
Estimate against measurement, compound 4: 1.5-fold (0.17 log units) above; measured number inside the range.
By their numbers in this assay, from the lowest: compounds 3 and 1 (each within the scatter of the next); then compound 4. At a limit, above all of these: compound 2.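

In this assay, chloro in place of hydrogen on an aromatic carbon, ortho to a large group, now has a step with a measured number at both ends: a 5.8-fold higher number from compound 3 to compound 4 (0.76 log units; beyond the scatter). The higher number under this change therefore appears on both cores shown, though the size of the two steps cannot be compared closely: the same change on two cores in this assay, an at least 8.4-fold higher number (0.92 log units; beyond the scatter) from compound 1 to compound 2 and a 5.8-fold higher number (0.76 log units; beyond the scatter) from compound 3 to compound 4; the limit leaves it open whether they differ With chloro present, 1-methyl-1H-pyrazol-4-yl in place of 3,5-dimethyl-1,2-oxazol-4-yl gives an at least 1.4-fold lower number from compound 2 to compound 4 (0.17 log units; that floor lies within the scatter), and this is only a floor set by the limit of compound 2: the same change on two cores in this assay, a 1.0-fold lower number (0.01 log units; within the scatter) from compound 1 to compound 3 and an at least 1.4-fold lower number (0.17 log units; that floor lies within the scatter) from compound 2 to compound 4; the limit leaves it open whether they differ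

The compounds shown carry only hydrogen or chloro at this place on the six-membered aromatic ring, so it remains open whether fluoro, methyl or methoxy there would raise the number as chloro does. On these data alone, it also remains open whether chloro elsewhere on that ring would produce a step of similar size, and whether compound 2 and compound 4 differ by more than the floor of their step.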